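This account rests on a few compounds, and the source may have more. Where it says the series, first, only, none or still open, it means among the compounds named here.

Measured in a functional assay on MDA-MB-231 cells (Homo sapiens) for cytotoxicity, read by MTT assay, with a stated time of 72 h; on this read-out lower numbers stand for stronger inhibition and higher numbers for weaker inhibition:
- compound 1 `O=C(CN1CCN(c2nnc(Cc3ccccc3)c3ccccc23)CC1)Nc1ccc(F)c(F)c1`: 2750 nM
- compound 2 `O=C(CN1CCN(c2nnc(Cc3ccncc3)c3ccccc23)CC1)Nc1c(F)cccc1F`: 1900 nM

Compound 2 stands within the scatter of compound 1, so the two numbers do not separate them. Compound 3 `O=C(CN1CCN(c2nnc(Cc3ccncc3)c3ccccc23)CC1)Nc1ccc(F)c(F)c1` follows from compound 2 by one change: 3,4-difluorophenyl in place of 2,6-difluorophenyl on an amide-type nitrogen. For the measured compounds named here, no measured pair isolates this change. Compound 1 also carries the 3,4-difluorophenyl and gives 2750 nM, so no shift beyond the scatter is expected. The expected step of a 1.2-fold higher number from compound 2 to compound 3 (0.06 log units; within the scatter) is small, with no clear direction. Compound 3 is estimated at 2200 nM, with an expected range of 900 nM to 5000 nM.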

Compound 3, half-maximal inhibitory concentration: 0.84 nM
Beside the measured number, compound 3's estimate is 2600-fold (3.42 log units) above it; the whole stated range lies above it.
By their numbers in this assay, from the lowest: compound 3; then compounds 2 and 1 (each within the scatter of the next).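

In this assay, 3,4-difluorophenyl in place of 2,6-difluorophenyl on the amide-type nitrogen gives a 2300-fold lower number from compound 2 to compound 3 (3.35 log units; beyond the scatter), so the fluorine pattern at this position matters strongly when pyridin-4-yl is present. Pyridin-4-yl in place of phenyl on the saturated chain carbon gives a 3300-fold lower number from compound 1 to compound 3 (3.52 log units; beyond the scatter), so the large gain appears only with both groups together among these compounds. Nothing available accounts for either step.

Still open, going by these compounds, is how phenyl on the chain carbon reads together with 2,6-difluorophenyl on the amide-type nitrogen. Also open, on these data alone, is whether 4-fluorophenyl at that nitrogen, or pyridin-3-yl on the chain carbon, would keep such a low number.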